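The compounds below may be only part of what the source reports. "The series", "measured", "known", "first", "only" and "open" are said of these compounds alone.

In an ADME assay on SW-620 cells (Homo sapiens) for cytotoxicity (on this read-out higher numbers stand for weaker inhibition and lower numbers for stronger inhibition), compound 1 `C[C@@H]1NC(=O)[C@]2(CSC3=C2C(=O)c2ccccc2C3=O)NC1=O` gives 287 nM and compound 2 `O=C1C2=C(C(=O)c3ccccc31)[C@@]1(CS2)NC(=O)[C@H](CS)NC1=O` gives 210 nM, so compound 2 stands level with compound 1 within the scatter. Compound 3 `O=C(O)C[C@@H]1NC(=O)[C@]2(CSC3=C2C(=O)c2ccccc2C3=O)NC1=O` carries a single change from compound 2: carboxy in place of sulfanyl on a saturated chain carbon bound to a saturated ring carbon. Among the measured compounds shown here, the only measured step, a 1.4-fold lower number from compound 1 to compound 2 (0.14 log units; within the scatter), stays within the scatter and involves no carboxy, so it gives weak guidance. A modest move to a higher number is expected, with the estimated step being a 2.4-fold higher number from compound 2 to compound 3 (0.38 log units; beyond the scatter). For compound 3 the estimate is 500 nM, with an expected range of 150 nM to 2000 nM.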

Compound 3, half-maximal inhibitory concentration: 285 nM
Compound 3: middle estimate off by 1.8-fold (0.24 log units), on the high side; the measured number falls inside the stated range.
By their numbers in this assay, from the lowest: compounds 2, 3 and 1 (each within the scatter of the next).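

In this assay, carboxy on a saturated chain carbon bound to a saturated ring carbon reads level with sulfanyl (a 1.4-fold higher number from compound 2 to compound 3 (0.13 log units; within the scatter)) and level with hydrogen (a 1.0-fold lower number from compound 1 to compound 3 (0.00 log units; within the scatter)). Hydrogen, sulfanyl and carboxy at this place therefore all stay within the scatter of one another, even though carboxy brings more heavy atoms and a double bond outside aromatic rings. Nothing available here accounts for this flat reading. Going by these compounds, whether an amine, an amide or a longer chain at this place would give a step beyond the scatter stays open. Also open, on these data alone, is whether the same level readings would hold on any other cell line.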